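Moving the furan attachment point in a small cyclic series

A few compounds are considered here, and "the series" means these few. Any claim that something is new, unique, unknown or untested is made for them only; others in the source may bear on it.

Measured so far in an assay on membranes from HEK293 cells for displacement of a labelled ligand from adenosine receptor A2b (Homo sapiens), read by scintillation counting, with a stated time of 30 min; on this read-out lower numbers stand for stronger inhibition and higher numbers for weaker inhibition:
- compound 1 `CCCOC(=O)C1=C(C)NC(=O)NC1c1ccoc1`: 1190 nM
- compound 2 `CC1=C(C(=O)CC(C)C)C(c2ccco2)NC(=O)N1`: 240 nM
- compound 3 `CC1=C(C(=O)OCC2CCC2)C(c2ccco2)NC(=O)N1`: 561 nM

Compound 3 stands second of the three numbers in this assay: compound 2 gives a lower number, compound 1 a higher one. Among the measured compounds shown here, the only single-point step among the measured compounds is a 2.3-fold higher number from compound 2 to compound 3 (0.37 log units; beyond the scatter), where cyclobutylmethoxy replaced isobutyl on a carbonyl carbon; that is a modest step and it concerns a different part of the molecule.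

Compound 4 `CC1=C(C(=O)OCC2CCC2)C(c2ccoc2)NC(=O)N1` differs from compound 3 by furan-3-yl in place of furan-2-yl on a saturated ring carbon. For the measured compounds named here, no measured pair isolates this change. Compound 1 also carries furan-3-yl, but it differs from compound 3 in its ester as well, so its higher number cannot be assigned to the furan alone.

For compound 4 the step of a 1.2-fold higher number from compound 3 to compound 4 (0.10 log units; within the scatter) is therefore expected to stay within the scatter, with a wide margin of uncertainty. Compound 4 is estimated at 700 nM, between 250 nM and 2000 nM.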

Compound 4, inhibition constant: 739 nM
Compound 4: the middle estimate sits 1.1-fold (0.02 log units) below what was measured; low and high end bracket the measured number.
By their numbers in this assay, from the lowest: compound 2; then compounds 3, 4 and 1 (each within the scatter of the next, the first and the last beyond it).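

In this assay, furan-3-yl in place of furan-2-yl on the saturated ring carbon gives a step that stays within the usual scatter (a 1.3-fold higher number from compound 3 to compound 4 (0.12 log units; within the scatter)), so the attachment point of the furan makes no readable difference in this pair. With furan-3-yl held fixed, cyclobutyl in place of ethyl in the ester chain also stays within the scatter (a 1.6-fold lower number from compound 1 to compound 4 (0.21 log units; within the scatter)), so neither change separates these compounds on this read-out. No outside measurement is available to explain either result.

Among the compounds shown here, it remains open whether the furan swap would stay as quiet alongside the isobutyl group of compound 2, the only compound here whose number lies beyond the scatter of more than one other. A phenyl or pyridine ring at this ring carbon could also show how much this position tolerates.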